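The source may hold more compounds than are shown below. What is called first, only, known or untested is meant among the compounds shown, and "the series" means these compounds.

Measured compounds:
compound 1 `CCNC(=O)c1cc(N)c(Nc2ccc(C#N)cc2)cc1Oc1c(C)cc(/C=C/C#N)cc1C` gives 2.32 h in an ADME assay on microsomes from liver (Homo sapiens) for metabolic stability, read by LC-MS, using NADPH, with a stated time of 45 min, tested at 1 uM; on this read-out higher numbers stand for a longer-lived compound and lower numbers for a shorter-lived compound
compound 2 `Cc1cc(/C=C/C#N)cc(C)c1Oc1cc(Nc2ccc(C#N)cc2)c(N)cc1C(=O)NN` gives 0.6 h in this assay

Within the data shown here, compound 2 stands at the lower of the two numbers so far; its nearest neighbour is compound 1, and the only characterised step, a 3.9-fold lower number from compound 1 to compound 2 (0.59 log units; beyond the scatter), runs downward and beyond the scatter. Compound 3 `Cc1cc(/C=C/C#N)cc(C)c1Oc1cc(Nc2ccc(C#N)cc2)c(N)cc1C(N)=O` is not yet measured. It differs from compound 2 by hydrogen in place of amino on an amide-type nitrogen, which gives the simple primary carbamoyl group in place of the aminocarbamoyl group.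

Among the measured compounds shown here, no measured pair shows this exact change. For the measured compounds named here, the one step on record, a 3.9-fold lower number from compound 1 to compound 2 (0.59 log units; beyond the scatter), touches the same amide-type nitrogen and is the only guide. Since that step produced the low number of compound 2, and compound 3 removes the group that entered there, the likeliest expectation is a partial return toward the number of compound 1, though without a matching pair the direction is not secure. The working expectation for compound 3 is a modest upward step, a 2.0-fold higher number from compound 2 to compound 3 (0.30 log units; within the scatter), beyond the scatter but smaller than the full gap back to compound 1. Compound 3 is therefore estimated at 1.2 h, within the range 0.5 h to 3 h.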

Compound 3, half-life: 1.5 h
Estimate against measurement, compound 3: 1.3-fold (0.10 log units) below, within the range that was stated.
By their numbers in this assay, from the lowest: compound 2; then compounds 3 and 1 (each within the scatter of the next).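

In this assay, hydrogen in place of amino on the amide-type nitrogen gives a 2.5-fold higher number from compound 2 to compound 3 (0.40 log units; beyond the scatter) and so sets the aminocarbamoyl group of compound 2 apart from the simple carbamoyl group as well as from the ethyl amide. Hydrogen in place of ethyl at the same nitrogen gives a 1.5-fold lower number from compound 1 to compound 3 (0.19 log units; within the scatter) and so does not separate these two groups on this read-out, which leaves amino as the only one of the three substituents tied to a number clearly apart from the others. Nothing at hand gives a reason for this separation.

Going by these compounds, whether a longer chain such as propyl or butyl, a cyclopropyl ring, or a hydroxyl or methoxy group on this nitrogen would track with hydrogen and ethyl or with amino remains open, as does whether a substituted amino group such as methylamino or dimethylamino would keep the number of compound 2. All three compounds share one core, so the compounds shown also cannot tell whether the same ranking of these groups would hold on a core carrying a different group in place of the nitrile or the cyanovinyl chain.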